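From bromo to furan-2-yl: expected step for compound 4

The compounds below may be only part of what the source reports. "The series", "measured", "known", "first", "only" and "open" are said of these compounds alone.

Of the compounds shown here, three have been measured in a functional assay on CCRF-CEM cells (Homo sapiens) for antiproliferative activity, read by cell counting, with a stated time of 72 h; a lower number here means a stronger inhibitor, a higher number a weaker inhibitor. Compound 3 `C#C[C@@]1(O)[C@@H](CO)O[C@@H](n2cc(Br)c3c(N)ncnc32)[C@@H]1O` stands lowest of them at 30 nM. Compound 2 `C#C[C@@]1(O)[C@@H](CO)O[C@@H](n2cnc3c(-c4ccc(F)cc4)ncnc32)[C@@H]1O` gives 223000 nM, far higher and beyond the scatter. Compound 1 `C#C[C@@]1(O)[C@@H](CO)O[C@@H](n2cnc3c(-c4ccccc4)ncnc32)[C@@H]1O` reads > 250000 nM, which is a limit and not a number. The evidence at that end of the series amounts to the limit of > 250000 nM in this assay, at which 1 of the 3 values shown sits.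

The change under review leads to compound 4 `C#C[C@@]1(O)[C@@H](CO)O[C@@H](n2cc(-c3ccco3)c3c(N)ncnc32)[C@@H]1O`: furan-2-yl in place of bromo on an aromatic carbon, (furan-2-yl in place of bromo on an aromatic carbon).

Among the measured compounds shown here, the only measured step is fluoro in place of hydrogen on an aromatic carbon, an at least 1.1-fold lower number from compound 1 to compound 2 (0.04 log units; that floor lies within the scatter). It starts from a limit, lies on another core and at another place, and so bears only weakly on this change. For the measured compounds named here, no measured step replaces bromo. The nearest hint is that compound 2, which carries an aromatic ring on its different core, gives 223000 nM. That hint points towards a higher number but cannot be carried over in size.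

A moderate loss is therefore expected, as a 6.7-fold higher number from compound 3 to compound 4 (0.82 log units; beyond the scatter), with wide uncertainty in this assay. For compound 4 the estimated value is 200 nM, with an expected range of 20 nM to 5000 nM.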

Compound 4, half-maximal inhibitory concentration: 17000 nM
Estimate against measurement, compound 4: 85-fold (1.93 log units) below; the whole stated range lies below it.
By their numbers in this assay, from the lowest: compound 3; then compound 4; then compound 2. At a limit, above all of these: compound 1.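

In this assay, among the compounds shown here, the replacement of bromo by furan-2-yl, on the aromatic carbon two ring bonds from the ring nitrogen, gives a 570-fold higher number from compound 3 to compound 4 (2.75 log units; beyond the scatter) and is the only measured step at this position on this core. The position is thus sensitive to what it carries: going from one heavy atom without a ring to five heavy atoms in a five-membered aromatic ring gives up most of the activity of compound 3, although compound 4 still gives a measurable number on the shared core. Nothing measured here accounts for the size of this loss.

With only bromo and furan-2-yl shown at this position, it remains open whether the loss goes with any aromatic ring there or with furan-2-yl alone, which a thiophen-2-yl group on the shared core would help to separate. From the compounds shown here alone, it also remains open whether a small group such as chloro, methyl or nitrile, or an amine on a short chain, would keep the number near that of compound 3.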